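Working notes: fluoro to ethoxy on the series

This account rests on a few compounds, and the source may have more. Where it says the series, first, only, none or still open, it means among the compounds named here.

compound 1 `COc1ccc(/C=C/c2cc(OC)cc(OC)c2/C=C/C(=O)c2cccc(OC)c2)cc1`: 4.3 ug/mL
compound 2 `COc1ccc(/C=C/c2cc(OC)cc(OC)c2/C=C/C(=O)c2ccc(F)cc2)cc1`: 5.3 ug/mL
compound 3 `CCOc1ccc(C(=O)/C=C/c2c(/C=C/c3ccc(OC)cc3)cc(OC)cc2OC)cc1`: not yet measured

Within the data shown here, in a functional assay on B16-F10 cells (Mus musculus) for antiproliferative activity, read by MTT assay, with a stated time of 48 h (on this read-out higher numbers stand for weaker inhibition and lower numbers for stronger inhibition), compound 2 gives 5.3 ug/mL, which lies within the usual scatter of compound 1, the only other compound measured so far. The next change is ethoxy in place of fluoro on an aromatic carbon, para to a large group.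

Among the measured compounds shown here, only one measured step bears on this change: a 1.2-fold higher number from compound 1 to compound 2 (0.09 log units; within the scatter). It also exchanges the aryl group on the carbonyl carbon, here 3-methoxyphenyl and 4-fluorophenyl, and it stays within the scatter. For the measured compounds named here, it is only a loose precedent, since no measured compound carries an ethoxy group and two compounds cannot establish a trend. On this evidence, no step beyond the scatter is expected, and neither direction is favoured.

The expected outcome is a 1.1-fold lower number from compound 2 to compound 3 (0.03 log units; within the scatter). The estimate for compound 3 is 5 ug/mL, with an expected range from 2.5 ug/mL to 10 ug/mL.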

Compound 3, half-maximal inhibitory concentration: 6.4 ug/mL
The estimate for compound 3 lay 1.3-fold (0.11 log units) below the measured number; the range from low to high includes it.
By their numbers in this assay, from the lowest: compounds 1, 2 and 3 (each within the scatter of the next).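

In this assay, ethoxy in place of fluoro on an aromatic carbon, para to a large group, gives a 1.2-fold higher number from compound 2 to compound 3 (0.08 log units; within the scatter). The exchange at this position therefore brings in 3 heavy atoms and 1 hydrogen-bond acceptor where fluoro had 1 heavy atom and none, and the number stays within the scatter, which the earlier pair could not show because it held no ethoxy group. Set against compound 1, the same aryl group gives a 1.5-fold higher number from compound 1 to compound 3 (0.17 log units; within the scatter), so all three exchanges on the carbonyl carbon seen so far, 3-methoxyphenyl, 4-fluorophenyl and 4-ethoxyphenyl, remain within the scatter of one another in this small set. No measured evidence is available to explain this flat result.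

Among these compounds, still open is whether an amine, a carboxylic acid or a longer alkoxy chain at this position would give a step beyond the scatter, since ethoxy and fluoro are the only two groups compared directly here. Also open, from the compounds shown here alone, is whether the unsubstituted phenyl group on the carbonyl carbon would stand apart from compound 1, compound 2 and compound 3 in this assay.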